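Benzothiazole for Benzimidazole in Thiourea-Linked Benzodioxane Amides

This account rests on a few compounds, and the source may have more. Where it says the series, first, only, none or still open, it means among the compounds named here.

Measured compounds:
compound 1 `N#Cc1ccc2[nH]c(-c3cccc(NC(=S)NC(=O)c4ccc5c(c4)OCCO5)c3)nc2c1` — "not determined" (no result reported)
compound 2 `O=C(NC(=S)Nc1cccc(-c2nc3ccccc3[nH]2)c1)c1ccc2c(c1)OCCO2` — 500 nM

Only compound 2 carries a number here. Among the compounds with values here, in a functional assay on MDA-MB-231 cells (Homo sapiens) for inhibition, read by colorimetric assay and crystal violet staining, with a stated time of 72 h (on this read-out higher numbers stand for weaker inhibition and lower numbers for stronger inhibition), compound 2 gives 500 nM, which is the sole value shown. In this assay compound 1 stands at "not determined" (no result reported), so compound 2 cannot be ranked against anything. Compound 3 `O=C(NC(=S)Nc1cccc(-c2nc3ccccc3s2)c1)c1ccc2c(c1)OCCO2` differs from compound 2 by 1,3-benzothiazol-2-yl in place of 1H-benzimidazol-2-yl on an aromatic carbon, in words a 1,3-benzothiazol-2-yl in place of a 1H-benzimidazol-2-yl on an aromatic carbon. Within the data shown here, no measured pair in this set isolates such a change, so there is no step to lean on. Among the measured compounds shown here, with a single anchor and no comparable step, the account expects at most a modest shift, most likely a slight weakening that may not clearly exceed the usual scatter. Compound 3 is therefore estimated at 800 nM, with a range from 250 nM to 2500 nM, which amounts to an expected step of a 1.6-fold higher number from compound 2 to compound 3 (0.20 log units; within the scatter).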

Compound 3, half-maximal inhibitory concentration: > 10000 nM
Compound 3 was reported as a limit; the forecaster's own chance of this, stated with the estimate: 10%; middle value at least 12-fold (1.09 log units) away from the limit.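

Setting a 1,3-benzothiazol-2-yl in place of the 1H-benzimidazol-2-yl gives an at least 20-fold higher number from compound 2 to compound 3 (1.30 log units; beyond the scatter) in this assay, the first measured sign that this place on the six-membered aromatic ring responds strongly to the group it carries. The two groups match in heavy atoms and ring types, but the entering group has no hydrogen-bond donor and carries a sulfur where the leaving group has a nitrogen, so a change this small in count is enough to produce the step. Compound 3 stands at a limit rather than a number, so the full size of the step stays unknown: the limit of > 10000 nM in this assay, at which 1 of the 3 values shown sits.

The compounds shown cannot separate the loss of the hydrogen-bond donor from the arrival of the sulfur, a question that a 1-methyl-1H-benzimidazol-2-yl or a 1,3-benzoxazol-2-yl at this place would address. The nitrile of compound 1 also cannot be read, as that compound has no value.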